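Amine substituent change from compound 3 to compound 4

This account rests on a few compounds, and the source may have more. Where it says the series, first, only, none or still open, it means among the compounds named here.

Within the data shown here, compound 1 `COC(=O)c1ccc(N2CCC(O)(Cn3cnc4c(Br)n(C)nc4c3=O)CC2)c(Cl)c1` is the only member of this set with a number: in an assay on Sf21 cells for inhibition of ubiquitin carboxyl-terminal hydrolase 7 (Homo sapiens), read by spectrophotometry, with stated times of 30 min and 2 h (on this read-out higher numbers stand for weaker inhibition and lower numbers for stronger inhibition), compound 1 gives 157 nM. Compound 2 `O=c1c2cnn(-c3ccc(F)cc3)c2ncn1CC1(O)CCN(Cc2ccccc2)CC1` carries a benzyl group on the ring amine nitrogen; in this assay compound 2 gives "not determined" (no result reported). Compound 3 `COC(=O)C(c1ccccc1Cl)N1CCC(O)(Cn2cnc3c(cnn3-c3ccc(F)cc3)c2=O)CC1` shares the core of compound 2 and differs from it only at the ring amine nitrogen; in this assay compound 3 gives "not determined" (no result reported). So compound 3 stands nowhere on the numbers: no result and no limit is recorded for it, and the same holds for compound 2.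

Compound 4 `O=c1c2cnn(-c3ccc(F)cc3)c2ncn1CC1(O)CCN(Cc2ccc(Cl)cc2)CC1` is the next entry. The change is 4-chlorobenzyl in place of (2-chlorophenyl)(methoxycarbonyl)methyl on an amine nitrogen in a ring. Among the measured compounds shown here, no pair of measured compounds differing in one place exists here, so no step size can be read for this change in either direction, and no size beyond the scatter can be claimed. For the measured compounds named here, the only anchor is compound 1 with 157 nM, which differs from compound 4 both in the core substituents and at the ring amine nitrogen. Compound 4 is therefore expected, with wide uncertainty, to give about 600 nM in this assay, within 100 nM to 6000 nM.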

Compound 4, half-maximal inhibitory concentration: 8000 nM
Estimate against measurement, compound 4: 13-fold (1.12 log units) below; measured number outside the range, above it.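

Among these compounds, compound 3 has no number in this assay, so no step to compound 4 can be read. The compounds shown leave open how the substituent on the ring amine nitrogen alone shifts inhibition on the shared core, and no measurement here bears on the result.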